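The compounds below may be only part of what the source reports. "The series", "measured", "known", "first", "only" and "open" are said of these compounds alone.

The measured compounds are these. Compound 1, `O=C(CCc1ccc(Cl)cc1)C(=O)NCCCCc1ccccc1`, gives 1000 nM in an assay on HEK-293T cells for inhibition of phospholipase A and acyltransferase 3 (Homo sapiens), with stated times of 30 min and 20 min; a higher number here means a weaker inhibitor, a lower number a stronger inhibitor. Compound 2, `CCOC(=O)C(F)(F)C(O)CCc1ccccc1`, returns only > 10000 nM in this assay, which is a limit of the assay and not a number. Compound 3, `CCNC(=O)C(=O)CCc1ccc(Cl)cc1`, gives 7940 nM in this assay.

Among the two numbers shown, compound 3 stands highest. Its nearest neighbour is compound 1, and the step of a 7.9-fold higher number from compound 1 to compound 3 (0.90 log units; beyond the scatter) lies beyond the scatter. Compound 2 sits at the limit of > 10000 nM in this assay, at which 1 of the 3 values shown sits, and so offers no number for comparison.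

Compound 4, `O=C(CCc1ccc(Cl)cc1)C(=O)N1CCCC1`, is not yet measured. It differs from compound 3 by pyrrolidin-1-yl in place of ethylamino on a carbonyl carbon. No measured step alters the amide-type nitrogen itself: the single step shown, a 7.9-fold higher number from compound 1 to compound 3 (0.90 log units; beyond the scatter), changes a substituent on the chain two bonds along from that nitrogen, so it bears on the present change only loosely, by showing that alterations in that part of the molecule can shift the number by a modest amount. In this assay compound 4 is therefore expected to move by a small step, more likely downward than upward, perhaps not beyond the scatter, the expected step being a 1.6-fold lower number from compound 3 to compound 4 (0.20 log units; within the scatter). The estimate for compound 4 is 5000 nM, expected to fall between 1500 nM and 15000 nM.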

Compound 4, half-maximal inhibitory concentration: > 10000 nM
Compound 4 gave a limit, no number (the forecaster's own chance of this, stated with the estimate: 25%); middle value at least 2.0-fold (0.30 log units) away from the limit.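

For the compounds shown here, this is the first measured change at the amide-type nitrogen itself: pyrrolidin-1-yl replaces ethylamino on a carbonyl carbon, so the one hydrogen-bond donor counted for ethylamino is gone, and in this assay the result is an at least 1.2-fold higher number from compound 3 to compound 4 (0.10 log units; that floor lies within the scatter). Going by these compounds, compound 4 gives > 10000 nM, which is a limit of the assay and not a number, so only the floor of this step can be read and its true size stays unknown. The change brought no lower number, and a second compound now stands at the weak end of the set: the limit of > 10000 nM in this assay, at which 2 of the 4 values shown sit.

The compounds shown leave open whether the result goes with the loss of the amide hydrogen or with the ring, as compound 4 changes both at once, and an open-chain dimethylamino group on the same carbonyl carbon would separate the two. Also open, on these data alone, is whether a larger ring such as piperidin-1-yl, or a ring carrying a longer chain ending in phenyl, would bring the number back within the range of the assay.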